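Swapping an Ethyl for Trifluoromethyl on the Fused Ring

A few compounds are considered here, and "the series" means these few. Any claim that something is new, unique, unknown or untested is made for them only; others in the source may bear on it.

Measured in an assay on membranes from Chem-1 cells for displacement of a labelled ligand from prostaglandin E2 receptor EP3 subtype (Homo sapiens), read by scintillation counting, with a stated time of 2 h; on this read-out lower numbers stand for stronger inhibition and higher numbers for weaker inhibition:
- compound 1 `CCc1cccc2ccc(-c3ccc(C(/C=C4\OC(=O)NC4=O)(CC)CC)c(=O)[nH]3)cc12` gives 17 nM
- compound 2 `CC(C)[C@@H](c1ccc(-c2ccc3cccc(F)c3c2)[nH]c1=O)[C@@H]1OC(=O)NC1=O` gives 85 nM
- compound 3 `CCC(CC)C(/C=C1\OC(=O)NC1=O)c1ccc(-c2ccc3cccc(F)c3c2)[nH]c1=O` gives 13 nM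

Compound 1 stands second highest of these three numbers. Its nearest neighbour is compound 3, whose number is lower by a margin within the usual scatter, so the two cannot be told apart. Compound 2 lies furthest away, with a higher number beyond the scatter. Compound 4 `CCC(/C=C1\OC(=O)NC1=O)(CC)c1ccc(-c2ccc3cccc(C(F)(F)F)c3c2)[nH]c1=O` keeps the whole core of compound 1 and differs in one place: trifluoromethyl in place of ethyl on an aromatic carbon. Among the compounds with values here, no measured pair shows this particular change, so the size of its effect in this assay is unknown. The step of a 1.2-fold higher number from compound 1 to compound 4 (0.07 log units; within the scatter) is expected to stay within the scatter, in no clear direction. Compound 4 is therefore expected to give about 20 nM, with a likely range from 7 nM to 60 nM.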

Compound 4, inhibition constant: 230 nM
Estimate against measurement, compound 4: 12-fold (1.06 log units) below; measured number outside the range, above it.
By their numbers in this assay, from the lowest: compounds 3 and 1 (each within the scatter of the next); then compound 2; then compound 4.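

In this assay trifluoromethyl in place of ethyl on this aromatic carbon gives a 14-fold higher number from compound 1 to compound 4 (1.13 log units; beyond the scatter) and so marks a large step beyond the scatter. Within the data shown here, the earlier compounds included no pair that changed this position, so this is the first sign that the number depends strongly on the group placed here. The data shown offer no measurement that explains this step.

A single swap cannot show whether methyl, chlorine or methoxy here would stay close to ethyl or fall nearer trifluoromethyl. It also leaves open whether the same swap would have a similar effect on another core.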